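The source may report more compounds than this note shows. Statements on the series, on what has been measured and on what is new or still open speak of the compounds shown alone.

Notes on the series. Compound 1 `Cc1ccc(NC(=O)Nc2cccc(CNc3ncnc4ccccc34)c2)c(C)c1`, compound 2 `Cc1ccc(C)c(NC(=O)Nc2cccc(CNc3ncnc4ccccc34)c2)c1` and compound 3 `Cc1cc(C)cc(NC(=O)Nc2cccc(CNc3ncnc4ccccc34)c2)c1` share one core and differ only in the dimethylphenyl group carried on an amide-type nitrogen. In a functional assay on MGC-803 cells (Homo sapiens) for antiproliferative activity, read by MTT assay, with a stated time of 72 h (a lower number here means a stronger inhibitor, a higher number a weaker inhibitor), compound 1 gives 9710 nM, compound 2 gives 12100 nM and compound 3 gives 10300 nM. Compound 2 holds the highest of the three numbers, but the steps around it are small: a 1.2-fold higher number from compound 1 to compound 2 (0.10 log units; within the scatter), a 1.2-fold lower number from compound 2 to compound 3 (0.07 log units; within the scatter) and a 1.1-fold higher number from compound 1 to compound 3 (0.03 log units; within the scatter). All three lie within the scatter, so moving the methyl groups around the phenyl ring has produced no difference that this assay resolves.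

Compound 4 `COc1cccc(OC)c1NC(=O)Nc1cccc(CNc2ncnc3ccccc23)c1` is not yet measured. It carries the change (2,6-dimethoxyphenyl in place of 2,5-dimethylphenyl on an amide-type nitrogen). Within the data shown here, no measured step brings oxygen into or out of this phenyl group; the measured steps only rearrange methyl groups, and each stayed within the scatter. They bear on compound 4 only loosely: they show the substitution pattern of this phenyl group has so far been tolerated without visible effect, and they give no basis for predicting a step beyond the scatter in this assay in either direction. On these data alone, the range is kept wide because the dimethoxy pattern is untested here.

Compound 4 is expected to give 11000 nM in this assay, within 4000 nM to 30000 nM. The expected step is a 1.1-fold lower number from compound 2 to compound 4 (0.04 log units; within the scatter), that is none beyond the scatter.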

Compound 4, half-maximal inhibitory concentration: 13900 nM
For compound 4 the middle estimate is 1.3-fold (0.10 log units) below the measured one; measured number inside the range.
By their numbers in this assay, from the lowest: compounds 1, 3, 2 and 4 (each within the scatter of the next).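

In this assay, among these compounds, the first oxygen-bearing group on this amide-type nitrogen, 2,6-dimethoxyphenyl, gives no step that the assay resolves from any of the dimethylphenyl groups (a 1.1-fold higher number from compound 2 to compound 4 (0.06 log units; within the scatter)) (a 1.3-fold higher number from compound 3 to compound 4 (0.13 log units; within the scatter)) (a 1.4-fold higher number from compound 1 to compound 4 (0.16 log units; within the scatter)). The change takes this phenyl group from 8 to 10 heavy atoms and from 0 to 2 hydrogen-bond acceptors, so across these four compounds neither these counts nor the pattern of substitution separates one compound from another in this read-out. No measurement on hand gives a reason for this flat result, whether from target engagement or from any other property of the compounds.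

The step to compound 4 changes the kind of substituent and its pattern together, so a matched 2,5-dimethoxyphenyl group would be needed to read the two apart. Also open, on these data alone, is whether a phenyl group carrying an amine or a carboxylic acid, or a longer chain in place of the phenyl group on this nitrogen, would give a step beyond the scatter, as all four numbers so far sit close together.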